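Methoxy for Fluoro Across Two Related Cores

This account rests on a few compounds, and the source may have more. Where it says the series, first, only, none or still open, it means among the compounds named here.

Measured compounds:
compound 1, `Fc1cccc(Cc2nnc(Cn3nnc4ccccc43)o2)c1`, 368000 nM
compound 2, `COc1cccc(Cc2nnc(Cn3nnc4ccccc43)o2)c1`, 350000 nM
compound 3, `Fc1cccc(-c2nnc(Cn3nnc4ccccc43)o2)c1`, 451000 nM

In a functional assay on HepG2 cells (Homo sapiens) for antiproliferative activity, read by MTT assay, with a stated time of 24 h (on this read-out lower numbers stand for stronger inhibition and higher numbers for weaker inhibition), compound 1 gives 368000 nM and compound 2 gives 350000 nM. The two differ in one place, (methoxy in place of fluoro on an aromatic carbon), and the step is a 1.1-fold lower number from compound 1 to compound 2 (0.02 log units; within the scatter). In this assay compound 3 gives 451000 nM; the difference between the core of compound 3 and the core of compound 1 is not broken down here.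

Compound 4, `COc1cccc(-c2nnc(Cn3nnc4ccccc43)o2)c1`, has not yet been measured. It stands to compound 3 as compound 2 stands to compound 1: methoxy in place of fluoro on an aromatic carbon. The place descriptions of the two changes agree word for word, so the change is the same one made on a second core. Since the change on the first core gave a 1.1-fold lower number from compound 1 to compound 2 (0.02 log units; within the scatter), the step from compound 3 to compound 4 in this assay is expected to be equally small, a 1.0-fold lower number from compound 3 to compound 4 (0.02 log units; within the scatter). That expectation rests on a single precedent, the pair of compound 1 and compound 2, so it is held loosely. On this basis compound 4 is estimated at 430000 nM in this assay, with a range from 200000 nM to 900000 nM.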

Compound 4, half-maximal inhibitory concentration: 476000 nM
Compound 4: middle estimate off by 1.1-fold (0.04 log units), on the low side, within the range that was stated.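

In this assay, methoxy in place of fluoro on the core of compound 3 gives a 1.1-fold higher number from compound 3 to compound 4 (0.02 log units; within the scatter), so the second core repeats what the first core showed: a step too small to read. Set side by side, the two steps do not differ: the same change on two cores in this assay, a 1.1-fold lower number (0.02 log units; within the scatter) from compound 1 to compound 2 and a 1.1-fold higher number (0.02 log units; within the scatter) from compound 3 to compound 4, 1.1-fold (0.05 log units) apart, within the scatter of two such steps. This shows that, for these two pairs, the change carried from one core to the other without any step beyond the usual scatter, but it does not show that the change is without consequence in general, that the slightly different signs of the two steps mean anything, or that two pairs of compounds are enough to predict a third core.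

The compounds shown leave open whether a group of a different kind on the same aromatic carbon, such as an amine or a carboxylic acid, would move the number beyond the scatter, and whether either core would then respond as the other does. They also leave open whether the agreement between the two steps would hold on a core carrying a longer chain, or with fluoro and methoxy placed elsewhere on the six-membered aromatic ring.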